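Side-chain variation at the amino-ester position, oral tail flick

The source may report more compounds than this note shows. Statements on the series, on what has been measured and on what is new or still open speak of the compounds shown alone.

Measured so far:
compound 1, `N=C(N)NCCC[C@H](NC(=O)CN(c1ncnc2c1ncn2C1CCCCO1)C1CC1)C(=O)OCc1ccccc1`, 34.3% in a functional assay on the whole organism (Tail, strain ICR) with Mus musculus as the target, in the tail flick test, with a stated time of 30 min, at a dose of 25 umol/kg by the oral route; a higher number here means a stronger effect of the compound at the dose given, a lower number a weaker effect
compound 2, `NC(=O)CC[C@H](NC(=O)CN(c1ncnc2c1ncn2C1CCCCO1)C1CC1)C(=O)OCc1ccccc1`, 47% in this assay

Compound 2 stands highest of the two numbers in this assay; compound 1 lies below it, and the step of a number 12.7 percentage points higher from compound 1 to compound 2 (beyond the scatter) is beyond the scatter.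

Compound 3, `CSCC[C@H](NC(=O)CN(c1ncnc2c1ncn2C1CCCCO1)C1CC1)C(=O)OCc1ccccc1`, is not yet measured in this assay. It differs from compound 2 by methylsulfanyl in place of carbamoyl on a saturated chain carbon, three bonds along the chain from an amide-type nitrogen and a carbonyl carbon.

Among the compounds with values here, only one measured step touches the same saturated chain carbon, and that is a number 12.7 percentage points higher from compound 1 to compound 2 (beyond the scatter), a modest move; it does not involve methylsulfanyl, so it bears on compound 3 only in showing that a change at this place shifts the number modestly rather than strongly. Within the data shown here, with no closer precedent, compound 3 is expected to sit near compound 2, with a step of a number 5 percentage points lower from compound 2 to compound 3 (within the scatter) that may lie within the scatter. The estimate for compound 3 in this assay is 42%, in the range 26% to 58%.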

Compound 3, a percentage reported as activity, at one dose (the size of the read-out at that dose, not a potency): 30%
The estimate for compound 3 lay 12 percentage points above the measured number, within the range that was stated.
By their numbers in this assay, from the lowest: compounds 3 and 1 (each within the scatter of the next); then compound 2.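

In this assay, methylsulfanyl in place of carbamoyl gives a number 17 percentage points lower from compound 2 to compound 3 (beyond the scatter), so this saturated chain carbon responds to a second change of modest size, and a side chain without the group of 5 heavy atoms of compound 1 can also fall short of compound 2. The other step, a number 4.3 percentage points lower from compound 1 to compound 3 (within the scatter), shows that two quite different groups at this place, one of 5 heavy atoms and one of 2, give readings that cannot be told apart, leaving carbamoyl as the only one of the three that stands clear of the others. Nothing measured here accounts for this difference between the side chains.

Still open, on these data alone, is whether the higher reading belongs to carbamoyl alone, or whether an amine, a carboxylic acid or a longer chain ending in carbamoyl would match compound 2. Also open, as far as these compounds go, is whether this order holds at other doses and times.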